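Amide variation at the carbonyl: compound 2 to compound 3

The source may report more compounds than this note shows. Statements on the series, on what has been measured and on what is new or still open speak of the compounds shown alone.

Compound 2 `CC(C)c1c(C(=O)N2CCCC2c2ccccc2)nn(-c2ccc(F)cc2)c1OC[C@@H](O)C[C@@H](O)CC(=O)O` stands level with compound 1 `CCN(Cc1ccccc1)C(=O)c1nn(-c2ccc(F)cc2)c(OC[C@@H](O)C[C@@H](O)CC(=O)O)c1C(C)C`: in an assay on microsomes from liver for inhibition of 3-hydroxy-3-methylglutaryl-coenzyme A reductase (Rattus norvegicus) (a lower number here means a stronger inhibitor, a higher number a weaker inhibitor), compound 2 gives 14 nM, and compound 1 gives 14 nM. Within the data shown here, the one step measured so far at this carbonyl carbon, no change at the digits printed from compound 1 to compound 2 (within the scatter), stayed within the scatter. Compound 3 `CC(C)c1c(C(=O)N(C)Cc2cccc(Cl)c2)nn(-c2ccc(F)cc2)c1OC[C@@H](O)C[C@@H](O)CC(=O)O` differs from compound 2 by (3-chlorobenzyl)(methyl)amino in place of 2-phenylpyrrolidin-1-yl on a carbonyl carbon. Because no change at the digits printed from compound 1 to compound 2 (within the scatter) showed no shift for an amide swap at the same place, a step of no change at the digits printed from compound 2 to compound 3 (within the scatter) is expected in this assay, none beyond the scatter. Compound 3 is therefore estimated at 14 nM in this assay, with a range from 7 nM to 28 nM.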

Compound 3, half-maximal inhibitory concentration: 8.3 nM
Compound 3: middle estimate off by 1.7-fold (0.23 log units), on the high side; measured number inside the range.
By their numbers in this assay, from the lowest: compounds 3, 1 and 2 (each within the scatter of the next).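

In this assay, the changes a 1.7-fold lower number from compound 2 to compound 3 (0.23 log units; within the scatter) and a 1.7-fold lower number from compound 1 to compound 3 (0.23 log units; within the scatter) place (3-chlorobenzyl)(methyl)amino on this carbonyl carbon level with both benzyl(ethyl)amino and 2-phenylpyrrolidin-1-yl. Across these three compounds, open-chain and ring-closed amine parts, with or without chlorine, therefore read alike at this place. No available evidence bears on this result.

Still open, from the compounds shown here alone, is whether an amide that keeps the amide hydrogen would stay level with these three. The same question applies to a benzyl group carrying a carboxylic acid or a dimethylamino group.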